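A pyrimidin-2-yl swap on the shared core

The source may hold more compounds than are shown below. What is called first, only, known or untested is meant among the compounds shown, and "the series" means these compounds.

Three measured compounds share one core and differ only in the group on an amine nitrogen in a ring. In a functional assay on NCI-H1975 cells (Homo sapiens) for inhibition, read by MTT assay, with a stated time of 72 h (a higher number here means a weaker inhibitor, a lower number a stronger inhibitor), compound 1 `CN1CCN(c2cc(C(F)(F)F)nc(SCc3ccc(C(F)(F)F)cc3)n2)CC1` gives 23900 nM, and compound 3 `FC(F)(F)c1ccc(CSc2nc(N3CCN(c4ccccn4)CC3)cc(C(F)(F)F)n2)cc1` gives 17400 nM. For compound 2 `CC(C)(C)OC(=O)N1CCN(c2cc(C(F)(F)F)nc(SCc3ccc(C(F)(F)F)cc3)n2)CC1`, this assay reports only a limit, > 50000 nM. Among the compounds with values here, compound 3 thus stands within the usual scatter of compound 1, the only other compound with an exact number.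

Compound 4 `FC(F)(F)c1ccc(CSc2nc(N3CCN(c4ncccn4)CC3)cc(C(F)(F)F)n2)cc1` changes one group of compound 3: pyrimidin-2-yl in place of pyridin-2-yl on an amine nitrogen in a ring, with pyrimidin-2-yl in place of pyridin-2-yl on the same amine nitrogen. Within the data shown here, no measured step tests this swap directly. The closest guide is a 1.4-fold lower number from compound 1 to compound 3 (0.14 log units; within the scatter), where replacing methyl with pyridin-2-yl left the number within the scatter. The two steps beyond the scatter, an at least 2.0-fold higher number from compound 1 to compound 2 (0.32 log units; beyond the scatter) and an at least 2.8-fold lower number from compound 2 to compound 3 (0.45 log units; beyond the scatter), both involve tert-butoxycarbonyl, a group that plays no part in this change. No step beyond the scatter is therefore expected in this assay. The estimate for compound 4 is 17000 nM, with an expected range of 8000 nM to 35000 nM. This estimate amounts to an expected 1.0-fold lower number from compound 3 to compound 4 (0.01 log units; within the scatter).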

Compound 4, half-maximal inhibitory concentration: 18300 nM
Compound 4: middle estimate off by 1.1-fold (0.03 log units), on the low side, and the stated range covers the measured number.
By their numbers in this assay, from the lowest: compounds 3, 4 and 1 (each within the scatter of the next). At a limit, above all of these: compound 2.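

In this assay, the swap of pyridin-2-yl for pyrimidin-2-yl on the amine nitrogen in a ring adds a second hetero atom to the aromatic ring, yet it gives a 1.1-fold higher number from compound 3 to compound 4 (0.02 log units; within the scatter), so this extra ring nitrogen brings no change that can be told from the scatter. Compound 4 also cannot be told apart from the methyl-bearing compound, with a 1.3-fold lower number from compound 1 to compound 4 (0.12 log units; within the scatter), so methyl, pyridin-2-yl and pyrimidin-2-yl on this nitrogen give numbers that the assay does not separate. Among the groups shown, only tert-butoxycarbonyl stands apart, with an at least 2.7-fold lower number from compound 2 to compound 4 (0.43 log units; beyond the scatter), and that step has no fixed size, since its starting compound gives only a limit: the limit of > 50000 nM in this assay, at which 1 of the 4 values shown sits.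

The compounds shown leave open whether any group on this nitrogen can bring the number down beyond the scatter, for example a phenyl ring, a carboxylic acid or a longer chain ending in an amine. They also leave open how the number responds to changes elsewhere on the shared core, such as replacing either trifluoromethyl group with a nitrile.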